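Replacing pyrrolidin-1-yl with 1H-imidazol-1-yl

This account rests on a few compounds, and the source may have more. Where it says the series, first, only, none or still open, it means among the compounds named here.

In a functional assay on the whole organism for agonist activity, with Mus musculus as the target (on this read-out lower numbers stand for an effect already at smaller amounts and higher numbers for an effect only at larger amounts of compound), compound 1 (`CC(=O)N(C)C(C)C#CCn1ccnc1`) gives 2 mg/kg as its dose for half-maximal effect, and compound 2 (`COC(=O)N(C)C(C)C#CCN1CCCC1`) gives 9.7 mg/kg on the same scale. Compound 2 thus holds the higher of the two numbers, and the gap lies beyond the usual scatter. Compound 3 (`COC(=O)N(C)C(C)C#CCn1ccnc1`) comes from compound 2 by one swap, 1H-imidazol-1-yl in place of pyrrolidin-1-yl on a saturated chain carbon bound to a triple-bonded carbon with 1H-imidazol-1-yl in place of pyrrolidin-1-yl on a saturated chain carbon bound to a triple-bonded carbon. Going by the values given here, no measured pair shows this swap alone, so any expectation is loose. Compound 1 also carries 1H-imidazol-1-yl, and its 2 mg/kg in this assay hints at a lower number. The estimated step is a 2.2-fold lower number from compound 2 to compound 3 (0.33 log units; beyond the scatter) towards a lower number, a modest move close to the scatter. For compound 3 the expected value is 4.5 mg/kg with an estimated range from 1.2 mg/kg to 17 mg/kg in this read-out.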

Compound 3, dose for half-maximal effect: 6.6 mg/kg
The estimate for compound 3 lay 1.5-fold (0.17 log units) below the measured number; measured number inside the range.
By their numbers in this assay, from the lowest: compound 1; then compounds 3 and 2 (each within the scatter of the next).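

In this assay, the swap at this saturated chain carbon bound to a triple-bonded carbon gives a 1.5-fold lower number from compound 2 to compound 3 (0.17 log units; within the scatter), so here a non-aromatic and an aromatic five-membered ring with the same count of heavy atoms cannot be told apart. The change that does register is methoxy in place of methyl on a carbonyl carbon, which gives a 3.3-fold higher number from compound 1 to compound 3 (0.52 log units; beyond the scatter); among these three compounds, that carbonyl substituent therefore counts for more than the ring swap. Nothing available explains either result.

A single pair cannot show whether the ring swap would read the same with methyl on the carbonyl carbon. Also open, from the compounds shown here alone, is how an open-chain amine such as dimethylamino would behave at the chain carbon, or ethoxy on the carbonyl carbon.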